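Fluorine and methyl on the aryl group of a chromenone core

This account rests on a few compounds, and the source may have more. Where it says the series, first, only, none or still open, it means among the compounds named here.

Compound 1 `CCC1=C(O)c2c(oc(-c3ccc(C(F)(F)F)cc3)cc2=O)C(CC)(CC)C1=O`: 10.4 uM
Compound 2 `CCC1=C(O)c2c(oc(-c3ccc(F)cc3)cc2=O)C(CC)(CC)C1=O`: 1.85 uM

In a functional assay on KBVIN cells (Homo sapiens) for antiproliferative activity, read by sulforhodamine B assay, with a stated time of 3 days (on this read-out higher numbers stand for an effect only at larger amounts of compound and lower numbers for an effect already at smaller amounts), compound 2 gives the lowest of the two numbers; the nearest is compound 1, which gives 10.4 uM. Compound 3 `CCC1=C(O)c2c(oc(-c3ccc(C)c(F)c3)cc2=O)C(CC)(CC)C1=O` differs from compound 2 by 3-fluoro-4-methylphenyl in place of 4-fluorophenyl on an aromatic carbon. Among the compounds with values here, the only measured step on this aromatic carbon is a 5.6-fold lower number from compound 1 to compound 2 (0.75 log units; beyond the scatter), where a smaller group gave a lower number. Here a methyl enters and the fluorine shifts, a change of a different kind, so only a small step is expected, if any, possibly a slightly higher number: a 1.4-fold higher number from compound 2 to compound 3 (0.15 log units; within the scatter). Compound 3 is therefore estimated at 2.6 uM, within 0.9 uM to 7.5 uM.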

Compound 3, concentration for half-maximal effect: 2.95 uM
Compound 3: the middle estimate sits 1.1-fold (0.05 log units) below what was measured; the range from low to high includes it.
By their numbers in this assay, from the lowest: compounds 2 and 3 (each within the scatter of the next); then compound 1.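

With 3-fluoro-4-methylphenyl in place of 4-fluorophenyl, this assay shows a 1.6-fold higher number from compound 2 to compound 3 (0.20 log units; within the scatter), so this aromatic carbon next to the ring oxygen accepts a larger aryl group with no change that can be told from the scatter. The earlier step showed only that this position can respond to a change in the aryl group; this one shows that not every change there counts. Nothing available explains this result. As far as these compounds go, the methyl and the shifted fluorine arrive together in compound 3, so their separate contributions remain unknown. From the compounds shown here alone, how a methoxy group, an amine or a carboxylic acid on the aryl ring would behave also remains open.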